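Dropping the Methoxy Group: Two Places, One Kind of Change

The source may hold more compounds than are shown below. What is called first, only, known or untested is meant among the compounds shown, and "the series" means these compounds.

Compound 1 `Cc1nc(C)c(C(=O)Oc2ccccc2/C=C/C(=O)O)nc1C`: 36700 nM
Compound 2 `COc1ccc(OC(=O)c2nc(C)c(C)nc2C)c(/C=C/C(=O)O)c1`: 48600 nM
Compound 3 `COc1ccc(/C=C/C(=O)O)cc1OC(=O)c1nc(C)c(C)nc1C`: 8800 nM

In a functional assay on EA.hy 926 cells (Homo sapiens) for cytotoxicity, read by MTT assay, with stated times of 24 h and 12 h (a higher number here means that more compound is needed for the effect, a lower number that less compound is needed), compound 3 gives the lowest of the three numbers, and both compound 1 and compound 2 lie beyond the scatter from it. Compound 3 and compound 2 are built from the same atoms joined differently; the difference between the two cores is not broken down here. Compound 4 `Cc1nc(C)c(C(=O)Oc2cccc(/C=C/C(=O)O)c2)nc1C` has not been measured. It differs from compound 3 by hydrogen in place of methoxy on an aromatic carbon. The same kind of change leads from compound 2 to compound 1, (hydrogen in place of methoxy on an aromatic carbon), and there it gave a 1.3-fold lower number from compound 2 to compound 1 (0.12 log units; within the scatter). The surroundings differ, though: in compound 2 the methoxy is meta to a 2-carboxyethenyl group and para to a large group, in compound 3 ortho to a large group and para to a 2-carboxyethenyl group, so the two changes are the same kind, not the same. Because a 1.3-fold lower number from compound 2 to compound 1 (0.12 log units; within the scatter) was within the scatter, compound 4 is expected in this assay to show a 1.1-fold higher number from compound 3 to compound 4 (0.06 log units; within the scatter). Compound 4 is therefore estimated at 10000 nM, between 4000 nM and 30000 nM.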

Compound 4, half-maximal effective concentration: 24000 nM
Beside the measured number, compound 4's estimate is 2.4-fold (0.38 log units) below it; low and high end bracket the measured number.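

Replacing the methoxy with hydrogen gave a 2.7-fold higher number from compound 3 to compound 4 (0.44 log units; beyond the scatter) in this assay and so did not repeat the result seen on the other core. The change therefore cannot be assumed to carry over from one core to the other in this series, as the two steps differ: the same change on two cores in this assay, a 1.3-fold lower number (0.12 log units; within the scatter) from compound 2 to compound 1 and a 2.7-fold higher number (0.44 log units; beyond the scatter) from compound 3 to compound 4, 3.6-fold (0.56 log units) apart, beyond the scatter of two such steps. With only these two pairs, however, this does not show why the steps differ, nor how the change would behave on any further core.

The compounds shown leave open what a hydroxyl, an ethoxy group or a chlorine in the place of the methoxy would do on either core. They also leave open whether an amide in place of the ester link would alter these steps.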